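A few compounds are considered here, and "the series" means these few. Any claim that something is new, unique, unknown or untested is made for them only; others in the source may bear on it.

Measured compounds:
Compound 1 `Cc1c(C(=O)Nc2c(F)cc(-c3cccc(F)c3)cc2F)nc2ccc(F)cc2c1O`: 4.85%
Compound 2 `Cc1ccc2nc(C(=O)Nc3c(F)cc(-c4cccc(F)c4)cc3F)c(C)c(C(=O)O)c2c1`: 15.2%
Compound 3 `CCc1ccc2nc(C(=O)Nc3c(F)cc(-c4cccc(F)c4)cc3F)c(C)c(C(=O)O)c2c1`: 1.68%

In a functional assay on Hep 3B2 cells (Homo sapiens) for antiproliferative activity, read by MTT assay, with a stated time of 24 h, tested at 0.41 ug/mL (on this read-out lower numbers stand for a weaker effect and higher numbers for a stronger effect at the one concentration tested), compound 3 gives the lowest of the three numbers, though only compound 2 stands beyond the scatter of it; compound 1 lies within it. Among the measured compounds shown here, the one measured step, a number 13.5 percentage points lower from compound 2 to compound 3 (beyond the scatter), concerns methyl on a chain carbon. Compound 4 `Cc1c(C(=O)Nc2c(F)cc(-c3cccc(F)c3)cc2F)nc2ccc(F)cc2c1C(=O)O` differs from compound 3 in that (fluoro in place of ethyl on an aromatic carbon). For the measured compounds named here, no measured step exchanges ethyl for fluoro, so the step of a number 13.5 percentage points lower from compound 2 to compound 3 (beyond the scatter) does not bear directly on it. Compound 1, which carries fluoro on its core, gives 4.85%, within the scatter of compound 3. No step beyond the scatter is therefore expected; compound 4 is estimated at 6% (0% to 20%), the expected step being a number 4.3 percentage points higher from compound 3 to compound 4 (within the scatter).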

Compound 4, a percentage reported as inhibition, at one concentration (the size of the read-out at that concentration, not a potency): 1.06%
Beside the measured number, compound 4's estimate is 4.9 percentage points above it; measured number inside the range.
By their numbers in this assay, from the lowest: compounds 4, 3 and 1 (each within the scatter of the next); then compound 2.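

In this assay, fluoro in place of ethyl on an aromatic carbon leaves the number within the scatter (a number 0.6 percentage points lower from compound 3 to compound 4 (within the scatter)), while fluoro in place of methyl at that carbon gives a step beyond it (a number 14.1 percentage points lower from compound 2 to compound 4 (beyond the scatter)), so among these three groups at this position, only methyl stands apart. With fluoro on the core, carboxy in place of hydroxy on an aromatic carbon also stays within the scatter (a number 3.8 percentage points lower from compound 1 to compound 4 (within the scatter)). Nothing at hand accounts for the methyl result. Open, as far as these compounds go, is how a methoxy group, an amine or a longer chain such as propyl would read at this aromatic carbon, and whether an amide in place of the carboxylic acid would move the number.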